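Swapping a dimethoxyphenyl for naphthyl on a sulfonamide chain

This account rests on a few compounds, and the source may have more. Where it says the series, first, only, none or still open, it means among the compounds named here.

Three sulfonamides have been tested in a functional assay on MIA PaCa-2 cells (Homo sapiens) for inhibition, read by MTT assay, with a stated time of 72 h; on this read-out higher numbers stand for weaker inhibition of growth and lower numbers for stronger inhibition of growth. Compound 2 `COc1ccc(CNCCCNS(=O)(=O)c2cc(C(F)(F)F)cc(C(F)(F)F)c2)cc1OC` gives 2800 nM, the lowest of the three numbers. Compound 3 `O=S(=O)(NCCCCCCNCc1ccc(Br)cc1)c1ccc(C(F)(F)F)cc1` gives 3830 nM, and this sits within the usual scatter of the number for compound 2, so the two cannot be told apart. Compound 1 `O=S(=O)(NCCNCc1cccc2ccccc12)c1cc(C(F)(F)F)cc(C(F)(F)F)c1` gives 26000 nM, a number clearly higher than that of compound 2, beyond the scatter. Compound 1 also carries the naphthalen-1-yl group, joined to the amine through a shorter chain than in compound 2.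

Compound 4 `O=S(=O)(NCCCNCc1cccc2ccccc12)c1cc(C(F)(F)F)cc(C(F)(F)F)c1` has not yet been measured. Its structure differs from compound 2 in one place: naphthalen-1-yl in place of 3,4-dimethoxyphenyl on a saturated chain carbon bound to an amine nitrogen. Going by the values given here, the aromatic group of compound 4 is therefore the one found in compound 1, while its chain matches compound 2. Because compound 1 gives 26000 nM with the same naphthalen-1-yl group, the number for compound 4 is expected to rise relative to compound 2, but the chain of compound 2 may keep it from going as far as compound 1. The step from compound 2 to compound 4 is estimated at a 2.9-fold higher number from compound 2 to compound 4 (0.46 log units; beyond the scatter), beyond the scatter. For compound 4 the estimate in this assay is 8000 nM, expected to fall within 2500 nM to 26000 nM.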

Compound 4, concentration for 50% growth inhibition: 2800 nM
For compound 4 the middle estimate is 2.9-fold (0.46 log units) above the measured one; the measured number falls inside the stated range.
By their numbers in this assay, from the lowest: compounds 2, 4 and 3 (each within the scatter of the next); then compound 1.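

In this assay, naphthalen-1-yl in place of 3,4-dimethoxyphenyl on a saturated chain carbon bound to an amine nitrogen gives no change at the digits printed from compound 2 to compound 4 (within the scatter) and so this position accepts the change in this assay, even though the group that enters has 2 six-membered aromatic rings and 0 hydrogen-bond acceptors, while the group that leaves has one such ring and 2 hydrogen-bond acceptors. Compound 4 also shares its naphthalen-1-yl group with compound 1, which differs from it in having the shorter chain, and the printed values show that this group does not by itself go with a high number: compound 1 gives 26000 nM while compound 4 gives 2800 nM on the chain of compound 2. No measurement shown here accounts for this result.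

The compounds shown leave open whether a plain phenyl, or a phenyl carrying a carboxylic acid or an amine, would keep the number at this place on the same chain. Also open, from the compounds shown here alone, is whether naphthalen-1-yl and 3,4-dimethoxyphenyl would still match on a longer chain.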